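The source may report more compounds than this note shows. Statements on the series, on what has been measured and on what is new or still open speak of the compounds shown alone.

Measured in an ADME assay on microsomes from liver (Mus musculus, strain CD1) for metabolic stability, read by HPLC, using NADPH, with a stated time of 30 min; a lower number here means slower removal, a higher number faster removal of the compound:

- Compound 1 `COc1cccc(NC(=O)c2nnn(Cc3ccc(C#N)cc3)c2N)c1` - 2.5 mL.min-1.g-1
- Compound 2 `COc1cccc(NC(=O)c2nnn(CC3CCNCC3)c2N)c1` - < 0.5 mL.min-1.g-1 (a limit of the assay, not a number)

Within the data shown here, compound 1 is the natural reference point, since at 2.5 mL.min-1.g-1 it holds the only true number in this small set. Compound 3 `COc1cccc(NC(=O)c2nnn(Cc3ccc(-n4cccn4)cc3)c2N)c1` differs from compound 1 in one place: 1H-pyrazol-1-yl in place of cyano on an aromatic carbon. Here 1H-pyrazol-1-yl stands in place of cyano on an aromatic carbon, while the rest of the molecule stays the same.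

Among the measured compounds shown here, only one measured step bears on this change, and it does so loosely. That step, an at least 5.0-fold lower number from compound 1 to compound 2 (0.69 log units; beyond the scatter), replaces the whole 4-cyanophenyl with piperidin-4-yl. For the measured compounds named here, it shows that this end of the molecule can move the number in this assay beyond the scatter, but no measured compound carries a pyrazolyl group. In compound 2 `COc1cccc(NC(=O)c2nnn(CC3CCNCC3)c2N)c1` an aromatic ring was removed and the number fell, whereas compound 3 gains one, so a modest move the other way is expected. The expected size is an estimated 2.0-fold higher number from compound 1 to compound 3 (0.30 log units; within the scatter), which is not far beyond the scatter. For compound 3 the expected value is 5 mL.min-1.g-1, with an estimated range of 2 mL.min-1.g-1 to 12 mL.min-1.g-1.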

Compound 3, intrinsic clearance in microsomes: 2.3 mL.min-1.g-1
Estimate against measurement, compound 3: 2.2-fold (0.34 log units) above; the measured number falls inside the stated range.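

In this assay, putting 1H-pyrazol-1-yl in place of cyano gives a 1.1-fold lower number from compound 1 to compound 3 (0.04 log units; within the scatter), so this pair cannot be told apart. The earlier step showed only that replacing the whole 4-cyanophenyl can move the number. This step shows that, with the six-membered aromatic ring kept, the group on this aromatic carbon can go from 2 heavy atoms to 5 heavy atoms and bring in a five-membered aromatic ring, with the number staying within the scatter.

From the compounds shown here alone, compound 2 remains a limit of the assay and not a number, so the full size of its step stays unknown: the limit of < 0.5 mL.min-1.g-1 in this assay, at which 1 of the 3 values shown sits. Whether an amine, a carboxylic acid or a longer chain on the same aromatic carbon would also stay within the scatter remains open, since only cyano and 1H-pyrazol-1-yl can be compared at this place.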